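N-alkyl shortening on a fluoro/bromo oxindole-benzimidazole series

A few compounds are considered here, and "the series" means these few. Any claim that something is new, unique, unknown or untested is made for them only; others in the source may bear on it.

The series is followed in a functional assay on BT-549 cells (Homo sapiens) for cytotoxicity, read by MTT assay, with a stated time of 48 h; on this read-out lower numbers stand for stronger inhibition and higher numbers for weaker inhibition. Compound 2 `CC(C)n1c(/C=C2/C(=O)Nc3ccc(F)cc32)nc2ccccc21` gives 26700 nM in this assay. Compound 1 `CCn1c(/C=C2/C(=O)Nc3ccc(F)cc32)nc2ccccc21` reaches only the limit of this assay, > 50000 nM, and no number is known for it. The step of an at least 1.8-fold higher number from compound 2 to compound 1 (0.27 log units; that floor lies within the scatter) is the change (hydrogen in place of methyl on a saturated chain carbon bound to an aromatic nitrogen and a saturated chain carbon); the floor of that step is consistent with the limit of > 50000 nM in this assay, at which 1 of the 3 values shown sits. Compound 3 `CCn1c(/C=C2/C(=O)Nc3ccc(Br)cc32)nc2ccccc21` carries bromine instead of fluorine; the difference between the cores of compound 3 and compound 2 is not broken down here, and in this assay compound 3 gives "not determined" (no result reported). Compound 4 `Cn1c(/C=C2/C(=O)Nc3ccc(Br)cc32)nc2ccccc21` is not yet measured and differs from compound 3 by hydrogen in place of methyl on a saturated chain carbon bound to an aromatic nitrogen. This is the same kind of change as the step from compound 2 to compound 1, not the same change: there the methyl leaves a saturated chain carbon bound to an aromatic nitrogen and a saturated chain carbon, here one bound to an aromatic nitrogen only. Among the compounds with values here, with compound 3 unmeasured and compound 1 sitting at the limit, the only anchor is compound 2 and its step to compound 1, which points toward a weaker number. Compound 4 is therefore expected to give about 60000 nM in this assay, within roughly 25000 nM to 150000 nM, and a limit rather than a number is likely.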

Compound 4, half-maximal inhibitory concentration: > 50000 nM
Compound 4 gave a limit, no number; the forecaster's own chance of this, stated with the estimate: 60%; the middle value is on the limit's open side.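

No step can be read from compound 3 to compound 4 in this assay. Compound 4 gives > 50000 nM, which is a limit and not a number. The read-out of the series now stands at this limit twice: the limit of > 50000 nM in this assay, at which 2 of the 4 values shown sit.

The compounds shown leave open what the change from ethyl to methyl does to the number in this assay, and how bromine and fluorine compare on otherwise identical structures.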